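The compounds below may be only part of what the source reports. "The series", "measured", "known", "first", "only" and "open" are said of these compounds alone.

Measured compounds:
compound 1 `N#Cc1ccc(Oc2cccc(NS(=O)(=O)c3cccc(C(F)(F)F)c3)c2)cc1`: 2200 nM
compound 2 `N#Cc1ccc(Oc2cccc(NCc3cccc(OC(F)(F)F)c3)c2)cc1`: > 15000 nM (a limit)
compound 3 `N#Cc1ccc(Oc2cccc(NS(=O)(=O)c3ccccc3)c2)cc1`: > 15000 nM (a limit)

In a functional assay on PLC5 cells (Homo sapiens) for inhibition, read by MTT assay, with a stated time of 24 h (a higher number here means a weaker inhibitor, a lower number a stronger inhibitor), compound 1 gives 2200 nM. Compound 2 reaches only a limit of the assay, > 15000 nM. Compound 3 likewise reaches only a limit, > 15000 nM. Among the measured compounds shown here, compound 1 is thus the one compound with a measured number; the other two sit at the limit of > 15000 nM in this assay, at which 2 of the 3 values shown sit. For the measured compounds named here, the single measured step is an at least 6.8-fold higher number from compound 1 to compound 3 (0.83 log units; beyond the scatter), which removes the trifluoromethyl. Compound 4 `CNC(=O)c1cc(Oc2cccc(NS(=O)(=O)c3cccc(C(F)(F)F)c3)c2)ccn1` keeps that trifluoromethyl and instead changes the other end of the shared core: 2-(methylcarbamoyl)pyridin-4-yl in place of 4-cyanophenyl on an oxygen on an aromatic ring. Going by the values given here, no measured step bears on this change, so no shift beyond the scatter is expected, a 1.5-fold lower number from compound 1 to compound 4 (0.17 log units; within the scatter). Compound 4 is estimated at 1500 nM, in a range from 300 nM to 8000 nM.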

Compound 4, half-maximal inhibitory concentration: 8400 nM
Compound 4: the middle estimate sits 5.6-fold (0.75 log units) below what was measured, outside the stated range (above it).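

The group on the oxygen at this end of the shared core is not interchangeable: replacing 4-cyanophenyl with 2-(methylcarbamoyl)pyridin-4-yl gives a 3.8-fold higher number from compound 1 to compound 4 (0.58 log units; beyond the scatter). The effect is modest, and compound 4 still gives a measured number, so the trifluoromethyl compound keeps measurable activity with either group, whereas other compounds reach only a limit: the limit of > 15000 nM in this assay, at which 2 of the 4 values shown sit.

The compounds shown do not separate the effect of the ring nitrogen from that of the methylcarbamoyl group. A plain pyridin-4-yl, or a phenyl ring carrying a carboxylic acid or a methylcarbamoyl group, would address this.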